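The compounds below may be only part of what the source reports. "The series", "measured", "known", "first", "only" and "open" are said of these compounds alone.

Measured so far in a functional assay on SGC-7901 cells (Homo sapiens) for antiproliferative activity, read by sulforhodamine B assay, with a stated time of 72 h; a higher number here means a weaker inhibitor, a lower number a stronger inhibitor:

- Compound 1 `Cc1ccc(/C=C(\C(=O)O)C(C)C)c2c1CC[C@H](C(C)(C)O)OC2=O`: > 100000 nM
- Compound 2 `CC(=O)Oc1cc2c(CCC=C(C)C)c(C)ccc2cc1C(C)C`: 34400 nM

Compound 1 gives only a limit of this assay, > 100000 nM, and not a number. Going by the values given here, that leaves compound 2, at 34400 nM, as the only true number so far, so there is no measured series to place it in.

Compound 3 `CC(=O)Oc1cc2c(CC[C@@H](O)C(C)(C)O)c(C)ccc2cc1C(C)C` keeps the core of compound 2 but carries 1,2-dihydroxy-2-methylpropyl in place of 2-methylprop-1-en-1-yl, on a saturated chain carbon, two bonds along the chain from an aromatic carbon: 1,2-dihydroxy-2-methylpropyl in place of 2-methylprop-1-en-1-yl on a saturated chain carbon, two bonds along the chain from an aromatic carbon.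

Among the compounds with values here, no measured pair shows what such a change does, so the expectation is a loose one. The expected change is a modest move towards weaker inhibition in this assay, with an estimated 1.7-fold higher number from compound 2 to compound 3 (0.24 log units; within the scatter). For compound 3 the estimate is 60000 nM, with an expected range of 20000 nM to 150000 nM.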

Compound 3, half-maximal inhibitory concentration: 47500 nM
The estimate for compound 3 lay 1.3-fold (0.10 log units) above the measured number; measured number inside the range.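

Going by these compounds alone, the first measured step at this position gives a 1.4-fold higher number from compound 2 to compound 3 (0.14 log units; within the scatter) in this assay, on replacing 2-methylprop-1-en-1-yl with 1,2-dihydroxy-2-methylpropyl on a saturated chain carbon, two bonds along the chain from an aromatic carbon. The change removes the double bond and adds two hydrogen-bond donors, two hydrogen-bond acceptors and a defined stereocentre, yet this assay does not separate the two compounds, so here the chain end accepts either group. Compound 1 gives only a limit and not a number, so it adds no further step: the limit of > 100000 nM in this assay, at which 1 of the 3 values shown sits.

The compounds shown leave open whether the opposite configuration at the new stereocentre would read the same. They also leave open whether an amine, a carboxylic acid or a longer chain at this place would give a clearly different number.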